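The source may hold more compounds than are shown below. What is called first, only, known or untested is meant among the compounds shown, and "the series" means these compounds.

Compound 1 `Cc1ccc(-n2nc(C(=O)Nc3ccc(Oc4ncnc5ccsc45)cc3)c(C)cc2=O)cc1` gives 23800 nM in a functional assay on MCF7 cells (Homo sapiens) for cytotoxicity, read by MTT assay, with a stated time of 72 h; a higher number here means a weaker inhibitor, a lower number a stronger inhibitor. Compound 2 `Cc1cc(=O)n(-c2ccc(F)cc2)nc1C(=O)Nc1ccc(Oc2ncnc3ccsc23)cc1` gives 4400 nM. Compound 3 `Cc1ccc(-n2nc(C(=O)Nc3ccc(Oc4ncnc5sccc45)c(F)c3)c(C)cc2=O)cc1` gives > 40000 nM, which is a limit of this assay and not a number, as the limit of > 40000 nM in this assay, at which 1 of the 3 values shown sits, shows.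

Compound 1 and compound 2 differ only by fluoro in place of methyl on an aromatic carbon; this change produced a 5.4-fold lower number from compound 1 to compound 2 (0.73 log units; beyond the scatter). Compound 4 `Cc1cc(=O)n(-c2ccc(F)cc2)nc1C(=O)Nc1ccc(Oc2ncnc3sccc23)c(F)c1` has not yet been measured. It differs from compound 3 by fluoro in place of methyl on an aromatic carbon, the same change at the same kind of place. The difference between the core of compound 1 and the core of compound 3 is not broken down here.

For compound 4 the expected value is 15000 nM. The expected range for compound 4 runs from 5000 nM to 60000 nM. The step this implies, an at least 2.6-fold lower number from compound 3 to compound 4 (0.42 log units; beyond the scatter), is an estimate resting on a 5.4-fold lower number from compound 1 to compound 2 (0.73 log units; beyond the scatter) applied to a starting point that is only a limit, so the outcome stays uncertain.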

Compound 4, half-maximal inhibitory concentration: 12300 nM
The estimate for compound 4 lay 1.2-fold (0.09 log units) above the measured number; measured number inside the range.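

Replacing 4-methylphenyl with 4-fluorophenyl on the core of compound 3 again lowered the number, giving an at least 3.2-fold lower number from compound 3 to compound 4 (0.51 log units; beyond the scatter). In this assay, the change therefore points the same way on both cores, and its effect on each lies beyond the scatter: the same change on two cores in this assay, a 5.4-fold lower number (0.73 log units; beyond the scatter) from compound 1 to compound 2 and an at least 3.2-fold lower number (0.51 log units; beyond the scatter) from compound 3 to compound 4; the limit leaves it open whether they differ. On these data alone, compound 3 gives > 40000 nM, which is a limit and not a number, so the full size of this second step stays unknown, and two cores cannot show that the change would carry to every core.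

The compounds shown leave open whether other groups in the same place, such as chloro, methoxy or an amine, would shift the number in the same direction. They also leave open how far this fluoro gain extends beyond these two cores.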